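Working notes: cytotoxicity across a nitro-bearing fused series

This account rests on a few compounds, and the source may have more. Where it says the series, first, only, none or still open, it means among the compounds named here.

Measured so far:
compound 1 `O=[N+]([O-])C1=CNc2nc(C(F)(F)F)nn2C1O` — 33000 nM
compound 2 `O=[N+]([O-])C1=NNc2nc(C(F)(F)F)nn2C1c1ccc(O)cc1O` — 108000 nM
compound 3 `CSc1nc2n(n1)C(c1c(O)cc(O)cc1O)C([N+](=O)[O-])=NN2` — 877000 nM

In an ADME assay on MDCK cells (Canis lupus familiaris) for cytotoxicity (a lower number here means that less compound is tolerated, a higher number that more compound is tolerated), compound 1 gives 33000 nM, the lowest of the three numbers. Compound 2 at 108000 nM lies beyond the scatter above compound 1, and compound 3 at 877000 nM lies further above still.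

Compound 4 `O=[N+]([O-])C1=CNc2nc(C(F)(F)F)nn2C1c1ccc(O)cc1O` is not yet measured. Relative to compound 1 the change is 2,4-dihydroxyphenyl in place of hydroxy on a saturated ring carbon. For the measured compounds named here, no pair of measured compounds differs in one place only, so no measured step guides this directly. Compound 2 carries the same 2,4-dihydroxyphenyl on a related core and gives 108000 nM, so an upward step beyond the scatter is expected, a 3.0-fold higher number from compound 1 to compound 4 (0.48 log units; beyond the scatter). Compound 4 is estimated at 100000 nM, with a range from 35000 nM to 300000 nM.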

Compound 4, half-maximal cytotoxic concentration: 258000 nM
The estimate for compound 4 lay 2.6-fold (0.41 log units) below the measured number, within the range that was stated.
By their numbers in this assay, from the lowest: compound 1; then compound 2; then compound 4; then compound 3.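

Working from the saturated ring carbon next to the ring nitrogen, 2,4-dihydroxyphenyl in place of hydroxy gives a 7.8-fold higher number from compound 1 to compound 4 (0.89 log units; beyond the scatter) in this assay, the first step in the series read between compounds that differ in one place. This position therefore accepts a much larger group, an aromatic ring included, with more compound tolerated rather than less. No measurement shown accounts for this step.

The compounds shown leave open whether the step follows the aromatic ring or its two hydroxy groups. A plain phenyl, or an amine, on this carbon would bear on that question.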